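Aryl variation at the double-bonded chain carbon

A few compounds are considered here, and "the series" means these few. Any claim that something is new, unique, unknown or untested is made for them only; others in the source may bear on it.

Compound 1, `O=C1N=C(N2CCC[C@H]2C(=O)Nc2ccc3ncnc(Nc4cccc(Cl)c4)c3c2)S/C1=C/c1cccc(Cl)c1`: in a functional assay on A549 cells (Homo sapiens) for antiproliferative activity, read by MTT assay (a lower number here means a stronger inhibitor, a higher number a weaker inhibitor), compound 1 gives > 50000 nM, a limit of the assay.
Compound 2, `O=C1N=C(N2CCC[C@H]2C(=O)Nc2ccc3ncnc(Nc4cccc(Cl)c4)c3c2)S/C1=C/c1ccccc1Cl`: in this assay compound 2 gives > 50000 nM, again only a limit.

Going by the values given here, compound 2 therefore stands at the limit and nowhere else on the numbers so far; both values shown sit there (the limit of > 50000 nM in this assay, at which 2 of the 2 values shown sit). Among the compounds with values here, the single measured step, a step that the two limits leave unreadable from compound 1 to compound 2, cannot be sized, since both ends are limits.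

Compound 3, `Cc1cccc(/C=C2/SC(N3CCC[C@H]3C(=O)Nc3ccc4ncnc(Nc5cccc(Cl)c5)c4c3)=NC2=O)n1`, is the next point: 6-methylpyridin-2-yl in place of 2-chlorophenyl on a double-bonded chain carbon bound to a double-bonded ring carbon. Within the data shown here, the only step that bears on this change is the unreadable one from compound 1 to compound 2, so no direction beyond the scatter can be drawn from it. The working expectation is that compound 3 stays at or near the limit in this assay. Compound 3 is estimated at 50000 nM, within 15000 nM to 150000 nM. The expected step is a number no higher from compound 2 to compound 3 (the limit leaves the size open).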

Compound 3, half-maximal inhibitory concentration: 8500 nM
The estimate for compound 3 lay 5.9-fold (0.77 log units) above the measured number; the measured number lies below the stated range.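

In this assay, the aryl group on the double-bonded chain carbon bound to a double-bonded ring carbon does affect the read-out, with an at least 5.8-fold lower number from compound 2 to compound 3 (0.76 log units; beyond the scatter) and an at least 5.8-fold lower number from compound 1 to compound 3 (0.76 log units; beyond the scatter) when 6-methylpyridin-2-yl enters. Both steps start from a limit, so they set only a minimum size, and the step between the two chlorophenyl compounds cannot be read. Compound 3 is the only compound shown with a measured number rather than a limit: the limit of > 50000 nM in this assay, at which 2 of the 3 values shown sit.

The entering group differs from 2-chlorophenyl in both its ring nitrogen and its methyl group, so the compounds shown do not separate the two changes. A plain pyridin-2-yl group or a 3-methylphenyl group at this position would show which of them carries the step.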